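This account rests on a few compounds, and the source may have more. Where it says the series, first, only, none or still open, it means among the compounds named here.

Of the compounds shown here, three built on one shared core have been tested in a functional assay on HeLa cells (Homo sapiens) for cytotoxicity, read by MTT assay, with a stated time of 48 h; a lower number here means a stronger inhibitor, a higher number a weaker inhibitor. Compound 1 `O=C1C(O)=C(C(c2ccc(F)cc2)c2c[nH]c3ccccc23)C(=O)c2ccccc21` gives 15800 nM. Compound 2 `COc1ccc(C(C2=C(O)C(=O)c3ccccc3C2=O)c2c[nH]c3ccccc23)cc1Br` gives 7320 nM, and compound 3 `O=C1C(O)=C(C(c2ccc([N+](=O)[O-])cc2)c2c[nH]c3ccccc23)C(=O)c2ccccc21` gives 14800 nM. Among these three numbers compound 3 stands second highest. Of the steps leading to it, a 1.1-fold lower number from compound 1 to compound 3 (0.03 log units; within the scatter), a step within the scatter, while a 2.0-fold higher number from compound 2 to compound 3 (0.31 log units; beyond the scatter).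

Compound 4 `O=C1C(O)=C(C(c2ccc(Cl)cc2)c2c[nH]c3ccccc23)C(=O)c2ccccc21` has not yet been measured. It differs from compound 3 in a single place: chloro in place of nitro on an aromatic carbon. The measured step that bears most directly on this change is the one where a 1.1-fold lower number from compound 1 to compound 3 (0.03 log units; within the scatter), since there too one small group on that aromatic carbon was exchanged for another without moving the number beyond the scatter. Going by the values given here, no other measured step touches this position. On that basis the change from nitro to chloro is expected to bring no step beyond the scatter, that is, the expected step is a 1.0-fold higher number from compound 3 to compound 4 (0.01 log units; within the scatter). Compound 4 is therefore estimated to give about 15000 nM, with a likely range from 7000 nM to 33000 nM.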

Compound 4, half-maximal inhibitory concentration: 37000 nM
Beside the measured number, compound 4's estimate is 2.5-fold (0.39 log units) below it; the whole stated range lies below it.
By their numbers in this assay, from the lowest: compound 2; then compounds 3 and 1 (each within the scatter of the next); then compound 4.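

In this assay, going by these compounds alone, the aromatic carbon carrying these groups proves more sensitive than the earlier compounds suggested: putting chloro in place of nitro gives a real shift (here a 2.5-fold higher number from compound 3 to compound 4 (0.40 log units; beyond the scatter)), although the exchange of fluoro for nitro had stayed within the scatter. Chloro also parts from fluoro (here a 2.3-fold higher number from compound 1 to compound 4 (0.37 log units; beyond the scatter)), so two halogens at this place are not interchangeable, and the widest gap is to the 3-bromo-4-methoxyphenyl group (here a 5.1-fold higher number from compound 2 to compound 4 (0.70 log units; beyond the scatter)), which leaves compound 4 the weakest of the four. Nothing measured here explains why chloro stands apart from both fluoro and nitro.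

Going by these compounds, whether an amine or a carboxylic acid at this place would raise or lower the number remains open. So does whether the bromo or the methoxy of compound 2 accounts for its lower number.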